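This account rests on a few compounds, and the source may have more. Where it says the series, first, only, none or still open, it means among the compounds named here.

Measured so far in a functional assay on HeLa cells (Homo sapiens) for cytotoxicity, read by MTT assay, with a stated time of 48 h; on this read-out higher numbers stand for weaker inhibition and lower numbers for stronger inhibition:
Compound 1 `COc1cc(-c2cc(COCc3cn(Cc4cc(-c5ccccc5)cnc4Cl)nn3)on2)cc(OC)c1OC` — 43100 nM
Compound 2 `COc1cc(-c2cc(COCc3cn(Cc4cc(C)cnc4Cl)nn3)on2)cc(OC)c1OC` — 57700 nM
Compound 3 `COc1cc(C2=NOC(COCc3cn(Cc4cc(C)cnc4Cl)nn3)C2)cc(OC)c1OC` — 50500 nM

Compound 1 and compound 2 share one core and differ in a single place: phenyl in place of methyl on an aromatic carbon. That change gave a 1.3-fold lower number from compound 2 to compound 1 (0.13 log units; within the scatter). Compound 3 carries a different core; how the core of compound 3 differs from that of compound 2 is not broken down here, and the two values lie within the scatter of each other.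

Compound 4 `COc1cc(C2=NOC(COCc3cn(Cc4cc(-c5ccccc5)cnc4Cl)nn3)C2)cc(OC)c1OC` is not yet measured. It differs from compound 3 by the same change: phenyl in place of methyl on an aromatic carbon. Within the data shown here, the only measured example of this change, from compound 2 to compound 1, stayed within the scatter, so a similarly small step is expected, a 1.3-fold lower number from compound 3 to compound 4 (0.10 log units; within the scatter). On that basis compound 4 is estimated at 40000 nM in this assay, with a plausible range from 20000 nM to 80000 nM.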

Compound 4, half-maximal inhibitory concentration: 7300 nM
Beside the measured number, compound 4's estimate is 5.5-fold (0.74 log units) above it; measured number outside the range, below it.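

In this assay, phenyl in place of methyl gave a 6.9-fold lower number from compound 3 to compound 4 (0.84 log units; beyond the scatter), so on the core of compound 3 this swap brings a clear drop in the number. The size of the step did not carry over from one core to the other: the same change on two cores in this assay, a 1.3-fold lower number (0.13 log units; within the scatter) from compound 2 to compound 1 and a 6.9-fold lower number (0.84 log units; beyond the scatter) from compound 3 to compound 4, 5.2-fold (0.71 log units) apart, beyond the scatter of two such steps. This shows that the core can decide how much the change matters, but it does not show why, and one pair on each core gives no rule for any further core in this series.

The compounds shown leave open how an amine, a carboxylic acid or a longer chain in the same place would behave on either core. Among these compounds, they also leave open whether phenyl is the only group that gives such a step on the core of compound 3.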